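Returning an aromatic ring to the amine-bound carbon

The source may hold more compounds than are shown below. What is called first, only, known or untested is meant among the compounds shown, and "the series" means these compounds.

The shared core carries a substituted aromatic amine, and the group on the saturated chain carbon bound to that nitrogen is what changes. Compound 1 `COc1ccc(CNc2ccc(-c3c(N)nc(N)nc3COCc3ccccc3)cc2)cc1` gives 7.7 nM in an in vitro assay on CHOK cells for displacement of a labelled ligand from growth hormone secretagogue receptor type 1 (Homo sapiens); on this read-out higher numbers stand for weaker inhibition and lower numbers for stronger inhibition. Compound 2 `CC(C)(C)CNc1ccc(-c2c(N)nc(N)nc2COCc2ccccc2)cc1` gives 67 nM in this assay, which is the higher of the two numbers shown; the step of an 8.7-fold higher number from compound 1 to compound 2 (0.94 log units; beyond the scatter) sets it apart from compound 1.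

Compound 3 `Nc1nc(N)c(-c2ccc(NCc3cnc4ccccc4c3)cc2)c(COCc2ccccc2)n1` carries the change (quinolin-3-yl in place of tert-butyl on a saturated chain carbon bound to a nitrogen on an aromatic ring), so a flat two-ring aromatic group stands where compound 2 has a branched saturated group. Going by the values given here, only one measured step bears on this: the step of an 8.7-fold higher number from compound 1 to compound 2 (0.94 log units; beyond the scatter), in which replacing an aromatic ring with tert-butyl on this carbon raised the number. Putting an aromatic ring back is expected to reverse much of that, so in this assay the step of a 5.6-fold lower number from compound 2 to compound 3 (0.75 log units; beyond the scatter) is expected, lowering the number beyond the scatter. Compound 3 is therefore estimated at 12 nM, with a plausible range from 3 nM to 50 nM.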

Compound 3, half-maximal inhibitory concentration: 130 nM
For compound 3 the middle estimate is 11-fold (1.03 log units) below the measured one, and the stated range ends below it.
By their numbers in this assay, from the lowest: compound 1; then compounds 2 and 3 (each within the scatter of the next).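

In this assay, putting an aromatic group on the saturated chain carbon bound to a nitrogen on an aromatic ring does not by itself give a low number: quinolin-3-yl in place of tert-butyl gives a 1.9-fold higher number from compound 2 to compound 3 (0.29 log units; within the scatter). Quinolin-3-yl in place of 4-methoxyphenyl gives a 17-fold higher number from compound 1 to compound 3 (1.23 log units; beyond the scatter), so among these three compounds the low number goes with 4-methoxyphenyl in particular, not with aromatic groups in general. No available measurement accounts for the gap between these two aromatic groups.

Quinolin-3-yl and 4-methoxyphenyl differ in several features at once, so these compounds cannot show whether the methoxy group, the second ring of quinolin-3-yl or its ring nitrogen matters most. As far as these compounds go, a plain phenyl group, a pyridin-3-yl group or a 4-ethoxyphenyl group on this carbon would each test one of these differences more directly, and how the number would respond to any of them remains open.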